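Swapping a Pyrrolidine Tail for a Methylpiperidine Tail

The compounds below may be only part of what the source reports. "The series", "measured", "known", "first", "only" and "open" are said of these compounds alone.

In a functional assay on HT-29 cells (Homo sapiens) for antiproliferative activity, read by MTT assay, with a stated time of 72 h (a lower number here means a stronger inhibitor, a higher number a weaker inhibitor), the measured compounds read as follows.
Compound 1 `COc1cc2c(Oc3ccc(NC(=O)C4(c5nnc(-c6ccc(F)cc6)o5)CC4)cc3F)ccnc2cc1OCCCN1CCCC1` gives 779 nM.
Compound 3 `COc1cc2c(Oc3ccc(NC(=O)c4ncc(-c5ccc(F)cc5)o4)cc3)ccnc2cc1OCCCN1CCC(C)CC1` gives 1890 nM.
Compound 2 `COc1cc2nccc(Oc3ccc(NC(=O)c4ncc(-c5ccc(F)cc5)o4)cc3)c2cc1OC` gives only a limit, > 100000 nM.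

Compound 1 has the lowest of the two numbers given, with compound 3 the nearest to it. Compound 2 sits at the limit of this assay (the limit of > 100000 nM in this assay, at which 1 of the 3 values shown sits). Compound 4 `COc1cc2c(Oc3ccc(NC(=O)C4(c5nnc(-c6ccc(F)cc6)o5)CC4)cc3F)ccnc2cc1OCCCN1CCC(C)CC1` is not yet measured; it differs from compound 1 by 4-methylpiperidin-1-yl in place of pyrrolidin-1-yl on a saturated chain carbon, three bonds along the chain from an oxygen on an aromatic ring. For the measured compounds named here, the one measured step touching this region is an at least 52-fold lower number from compound 2 to compound 3 (1.72 log units; beyond the scatter), where an entire basic tail was attached to a bare position. Here one saturated amine ring replaces another on the same chain, a far smaller change, so the step is expected to remain within the scatter. The estimated value for compound 4 in this assay is 900 nM, within 400 nM to 2000 nM, that is a 1.2-fold higher number from compound 1 to compound 4 (0.06 log units; within the scatter).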

Compound 4, half-maximal inhibitory concentration: 442 nM
Beside the measured number, compound 4's estimate is 2.0-fold (0.31 log units) above it, within the range that was stated.
By their numbers in this assay, from the lowest: compounds 4 and 1 (each within the scatter of the next); then compound 3. At a limit, above all of these: compound 2.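

On the core of compound 1, the ring at the end of the chain was exchanged for another with a 1.8-fold lower number from compound 1 to compound 4 (0.25 log units; within the scatter) in this assay. The earlier step set a basic tail against no tail at all, whereas this one compares two tails directly, and this assay does not tell 3-(pyrrolidin-1-yl)propyl and 3-(4-methylpiperidin-1-yl)propyl apart. Nothing shown gives a reason for this result. On these data alone, whether a morpholine ring, a dimethylamino group or a longer chain in the same place would also give a similar number remains open.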